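Dimethylamino for Chloro: Cytotoxicity Expected to Hold Steady

The source may report more compounds than this note shows. Statements on the series, on what has been measured and on what is new or still open speak of the compounds shown alone.

Three compounds share one core and differ only in the aryl group attached to it. In an ADME assay on Huh-7 cells (Homo sapiens) for cytotoxicity (a higher number here means that more compound is tolerated, a lower number that less compound is tolerated), compound 1 `CN1CCN(CCNCc2cn(-c3ccc(F)cc3F)nc2-c2ccc(OC(F)(F)F)cc2)CC1` gives 18000 nM and compound 3 `CN1CCN(CCNCc2cn(-c3ccc(F)cc3F)nc2-c2cccc(Cl)c2)CC1` gives 15000 nM. Compound 2 `Cc1ccc(-c2nn(-c3ccc(F)cc3F)cc2CNCCN2CCN(C)CC2)cc1` sits at the limit of > 20000 nM in this assay, at which 1 of the 3 values shown sits, so its value > 20000 nM is a limit, not a number. Of the two numbers, compound 3 holds the smaller, yet the gap is only a 1.2-fold lower number from compound 1 to compound 3 (0.08 log units; within the scatter), and the change is an at least 1.3-fold lower number from compound 2 to compound 3 (0.12 log units; that floor lies within the scatter). Compound 4 `CN1CCN(CCNCc2cn(-c3ccc(F)cc3F)nc2-c2cccc(N(C)C)c2)CC1` carries dimethylamino in place of chloro on an aromatic carbon. Going by the values given here, the steps that bear on this, a 1.2-fold lower number from compound 1 to compound 3 (0.08 log units; within the scatter) and an at least 1.3-fold lower number from compound 2 to compound 3 (0.12 log units; that floor lies within the scatter), both swap groups on this same ring and both stay within the scatter, so the step of a 1.1-fold higher number from compound 3 to compound 4 (0.05 log units; within the scatter) is expected to be no larger. Compound 4 is therefore estimated at 17000 nM, between 8000 nM and 30000 nM.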

Compound 4, half-maximal cytotoxic concentration: > 20000 nM
Compound 4: no number, only a limit; the forecaster's own chance of this, stated with the estimate: 35%; at least 1.1-fold (0.07 log units) between middle value and limit.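

Compound 4 gives > 20000 nM in this assay, which is a limit and not a number: the limit of > 20000 nM in this assay, at which 2 of the 4 values shown sit. Putting dimethylamino, with its one hydrogen-bond acceptor, where chloro has none gives an at least 1.3-fold higher number from compound 3 to compound 4 (0.12 log units; that floor lies within the scatter), and the wider aryl swap gives an at least 1.1-fold higher number from compound 1 to compound 4 (0.04 log units; that floor lies within the scatter), so neither step shows a real change at this position. The step between compound 2 and compound 4 cannot be read, as both values are limits.

Still open, from the compounds shown here alone, is whether a carboxylic acid or a primary amine at this place would move the number beyond the scatter.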